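Removing a methoxy group from a pyrazoline with a naphthyl arm

The compounds below may be only part of what the source reports. "The series", "measured", "known", "first", "only" and "open" are said of these compounds alone.

Measured so far:
compound 1, `COc1ccc(C2CC(c3ccco3)=NN2C(C)=O)cc1`, 15500 nM
compound 2, `COc1ccc(C2CC(c3ccco3)=NN2C(C)=O)cc1OC`, 12300 nM
compound 3, `COc1ccc(C2CC(c3cccc4ccccc34)=NN2C(C)=O)c(OC)c1OC`, 1220 nM

The three measured compounds were tested in a functional assay on PC-3 cells (Homo sapiens) for cytotoxicity, read by sulforhodamine B assay, with a stated time of 48 h; a higher number here means a weaker inhibitor, a lower number a stronger inhibitor. Compound 1 gives 15500 nM in this assay, and compound 2 gives 12300 nM. The two differ in one place: hydrogen in place of methoxy on an aromatic carbon. That step, a 1.3-fold higher number from compound 2 to compound 1 (0.10 log units; within the scatter), is small and within the scatter, so the two numbers cannot be ordered.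

Compound 3 stands apart, with the lowest number of the three at 1220 nM. Its core differs from that of compound 2 in more than one place, and the difference between the two cores is not broken down here.

Compound 4, `COc1ccc(C2CC(c3cccc4ccccc34)=NN2C(C)=O)cc1OC`, has not yet been measured in this assay. It is obtained from compound 3 by the following change: hydrogen in place of methoxy on an aromatic carbon. This is the same kind of change as that from compound 2 to compound 1, though the surroundings differ: in compound 3 the leaving methoxy sits ortho to a large group and ortho to a methoxy group and meta to a methoxy group, whereas in compound 2 it sits ortho to a methoxy group and meta to a large group. Within the data shown here, with only one earlier example of this kind of change, and that one within the scatter, a small step is expected. The estimated step from compound 3 to compound 4 in this assay is a 1.6-fold higher number from compound 3 to compound 4 (0.19 log units; within the scatter), resting on compound 2 to compound 1 having given a 1.3-fold higher number from compound 2 to compound 1 (0.10 log units; within the scatter). Compound 4 is therefore expected to give about 1900 nM, likely between 700 nM and 5000 nM.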

Compound 4, half-maximal inhibitory concentration: 2010 nM
The estimate for compound 4 lay 1.1-fold (0.02 log units) below the measured number, and the stated range covers the measured number.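

In this assay, replacing the methoxy group with hydrogen gives a 1.6-fold higher number from compound 3 to compound 4 (0.22 log units; within the scatter), so compound 3 and compound 4 cannot be ordered. Set beside the earlier case on a different core, this step cannot be told apart from it, and on the two cores shown the change behaves alike within what the assay can resolve: the same change on two cores in this assay, a 1.3-fold higher number (0.10 log units; within the scatter) from compound 2 to compound 1 and a 1.6-fold higher number (0.22 log units; within the scatter) from compound 3 to compound 4, 1.3-fold (0.12 log units) apart, within the scatter of two such steps. Among these compounds, this holds even though the methoxy group that leaves compound 3 sits ortho to a large group, ortho to a methoxy group and meta to a methoxy group, but two pairs that both lie within the scatter show only that the change stayed small in these two cases, not that it would stay small on every core.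

The compounds shown leave open what a different group would give at this aromatic carbon, such as a hydroxyl group, a fluorine atom or an amine, as only methoxy and hydrogen appear there. Also open, going by these compounds, is whether a longer chain, such as ethoxy, in place of the methoxy group would give a step beyond the scatter on either core.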